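This account rests on a few compounds, and the source may have more. Where it says the series, first, only, none or still open, it means among the compounds named here.

Of the compounds shown here, three built on one shared core have been tested in an ADME assay on PBMC cells (Homo sapiens) for cytotoxicity; a higher number here means that more compound is tolerated, a lower number that less compound is tolerated. Compound 1 `CC(CCNC(=O)c1c(Cl)cncc1Cl)N1CCC(C(Oc2ccncc2)c2ccc(Br)cc2)CC1` gives 31200 nM. Compound 2 `COc1cccc(OC(c2ccc(C(F)(F)F)cc2)C2CCN(C(C)CCNC(=O)c3c(Cl)cncc3Cl)CC2)n1` gives 32700 nM. Compound 3 `CC(CCNC(=O)c1c(Cl)cncc1Cl)N1CCC(C(O)c2ccc(Br)cc2)CC1` gives 198000 nM. Among these three numbers compound 2 stands second highest: its number and that of compound 1 lie within the scatter of each other, while the number of compound 3 lies clearly above both. Among the compounds with values here, the only step between two compounds that differ in a single place is a 6.3-fold higher number from compound 1 to compound 3 (0.80 log units; beyond the scatter), a change in which the aromatic ring on the oxygen is taken away altogether.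

Compound 4 `CC(CCNC(=O)c1c(Cl)cncc1Cl)N1CCC(C(Oc2ccccc2Cl)c2ccc(C(F)(F)F)cc2)CC1` has not yet been measured. It differs from compound 2 in one place: 2-chlorophenyl in place of 6-methoxypyridin-2-yl on an oxygen on a saturated carbon. The step from compound 1 to compound 3 sits at the same oxygen, but it removes the aromatic ring entirely, whereas here one aromatic ring replaces another. Within the data shown here, no measured step shows what such a swap of one ring for another does in this assay, so the guidance is weak. The step expected from this change is therefore a 1.0-fold lower number from compound 2 to compound 4 (0.01 log units; within the scatter), staying within the scatter. Compound 4 is estimated at 32000 nM in this assay, with a likely range from 14000 nM to 75000 nM.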

Compound 4, half-maximal cytotoxic concentration: 4400 nM
Estimate against measurement, compound 4: 7.3-fold (0.86 log units) above; the whole stated range lies above it.
By their numbers in this assay, from the lowest: compound 4; then compounds 1 and 2 (each within the scatter of the next); then compound 3.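

Putting 2-chlorophenyl in place of 6-methoxypyridin-2-yl on this oxygen gives a 7.4-fold lower number from compound 2 to compound 4 (0.87 log units; beyond the scatter) in this assay, so the number responds to which aromatic ring sits there, not only to whether one is present. The earlier step at the same oxygen, a 6.3-fold higher number from compound 1 to compound 3 (0.80 log units; beyond the scatter), removed the aromatic ring altogether and could not show this; the new step shows that one ring exchanged for another of the same size can also move the number beyond the scatter, and here it moves it downward. No measurement is at hand that would explain this drop.

The swap takes away the ring nitrogen and the methoxy group and brings in a chlorine in a single change, so the compounds shown leave open which of these parts accounts for the step. Going by these compounds, a plain phenyl, a methoxyphenyl or a chloropyridinyl on the same oxygen would begin to separate them, and it also remains open whether the swap would give a similar step with the bromophenyl of compound 1 in place of the trifluoromethylphenyl.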